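The compounds below may be only part of what the source reports. "The series", "measured", "known", "first", "only" and "open" are said of these compounds alone.

In an in vitro ADME assay on microsomes from liver (Rattus norvegicus) for metabolic stability (a higher number here means faster removal of the compound, a lower number slower removal), compound 3 (`CC[C@@H](NC(=O)c1ccc2c(c1)ncn2Cc1ccc(Cl)c(Cl)c1)c1ccccc1`) gives 3.3 mL.min-1.g-1 and is the starting point for this step. Compound 1 (`CCC(NC(=O)c1ccc2c(c1)nc(C)n2Cc1ccc(Cl)c(Cl)c1)c1ccccc1`) gives 2.5 mL.min-1.g-1 and lies within the scatter of compound 3, so these two values are not separated. Compound 2 (`Cc1nc2cc(C(=O)N[C@H](C)c3ccccc3)ccc2n1Cc1ccc(Cl)c(Cl)c1`) gives 1.4 mL.min-1.g-1 and this value lies beyond the scatter from that of compound 3.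

Compound 4 (`CC[C@@H](NC(=O)c1ccc2c(c1)ncn2Cc1ccc(F)cc1F)c1ccccc1`) is not yet measured. It departs from compound 3 as follows: 2,4-difluorophenyl in place of 3,4-dichlorophenyl on a saturated chain carbon bound to an aromatic nitrogen.

Among the measured compounds shown here, the only measured step (a 1.8-fold lower number from compound 1 to compound 2 (0.25 log units; within the scatter)) puts 1-phenylethyl in place of 1-phenylpropyl on an amide-type nitrogen and stays within the scatter. It does not touch the group that changes here. For the measured compounds named here, all three measured compounds carry 3,4-dichlorophenyl, so the data hold no direct precedent for this exchange.

Going by these compounds, without such a precedent, no step beyond the scatter is expected in this assay and the direction remains open. The expected step (a 1.3-fold lower number from compound 3 to compound 4 (0.12 log units; within the scatter)) is only an estimate and carries wide margins. For compound 4 the estimated value is 2.5 mL.min-1.g-1 with an expected range of 1.1 mL.min-1.g-1 to 5.5 mL.min-1.g-1 around it.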

Compound 4, intrinsic clearance in microsomes: 3.7 mL.min-1.g-1
For compound 4 the middle estimate is 1.5-fold (0.17 log units) below the measured one; the range from low to high includes it.
By their numbers in this assay, from the lowest: compounds 2, 1, 3 and 4 (each within the scatter of the next, the first and the last beyond it).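

With 2,4-difluorophenyl in place of 3,4-dichlorophenyl on a saturated chain carbon bound to an aromatic nitrogen, this assay gives a 1.1-fold higher number from compound 3 to compound 4 (0.05 log units; within the scatter) and so does not separate the two compounds. Among the compounds shown here, this is the first reading at this place, since compounds 1, 2 and 3 all carry 3,4-dichlorophenyl, and it shows that this exchange of one halogenated phenyl for another, with the heavy-atom count unchanged at 8, leaves the number within the scatter. No supporting data are available to explain why compound 3 and compound 4 are not separated.

The exchange alters both the halogen and the numbering of its places on the ring, so the contribution of each remains unresolved, and a 3,4-difluorophenyl, a 2,4-dichlorophenyl or an unsubstituted phenyl would be needed to take the two apart. Also open, going by these compounds, is whether a pyridyl ring or a methoxy-bearing phenyl at this place would stay within the scatter, and whether 2,4-difluorophenyl would read the same on the 1-phenylethyl amide of compound 2.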